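Methoxy on the pendant phenyl of the shared core

A few compounds are considered here, and "the series" means these few. Any claim that something is new, unique, unknown or untested is made for them only; others in the source may bear on it.

Compound 3 `Cc1nc2c3ccccc3ccc2c2nc3c(ccc4ccccc43)c(-c3ccccc3)c12` carries a plain phenyl on the shared core. In a functional assay on HCT-116 cells (Homo sapiens) for cytotoxicity, read by MTT assay, with a stated time of 48 h (a higher number here means a weaker inhibitor, a lower number a stronger inhibitor), compound 3 gives only a limit, > 80000 nM. Compounds 1 and 2 differ from it in that ring alone: compound 1 `Cc1nc2c3ccccc3ccc2c2nc3c(ccc4ccccc43)c(-c3ccccc3S)c12` with a 2-sulfanylphenyl gives 1420 nM in this assay, and compound 2 `Cc1nc2c3ccccc3ccc2c2nc3c(ccc4ccccc43)c(-c3cc([N+](=O)[O-])ccc3N)c12` with a 2-amino-5-nitrophenyl gives 6010 nM. The steps to compound 3 read an at least 56-fold higher number from compound 1 to compound 3 (1.75 log units; beyond the scatter) and an at least 13-fold higher number from compound 2 to compound 3 (1.12 log units; beyond the scatter). As far as these compounds go, both steps end at the limit (the limit of > 80000 nM in this assay, at which 1 of the 3 values shown sits), so their true size stays unknown. Compound 4 `COc1ccc(-c2c3ccc4ccccc4c3nc3c2c(C)nc2c4ccccc4ccc32)cc1` is the next variation on the same ring: methoxy in place of hydrogen on an aromatic carbon, placed on an aromatic carbon of the six-membered aromatic ring of carbon only, para to a large group. For the measured compounds named here, the two earlier substituents on that ring brought the number down from the limit by at least the sizes above, but methoxy is a different group at a different place, and no measured step gives its size directly. A return below the limit is expected, of uncertain extent. The step of an at least 2.6-fold lower number from compound 3 to compound 4 (0.42 log units; beyond the scatter) is the estimated change. Compound 4 is expected at 30000 nM, within 6000 nM to 80000 nM, with a fair chance that only a limit is again reported.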

Compound 4, half-maximal inhibitory concentration: > 80000 nM
Compound 4: only a limit was reported; the forecaster's own chance of this, stated with the estimate: 45%; middle value at least 2.6-fold (0.42 log units) away from the limit.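

Methoxy on an aromatic carbon of the pendant ring, para to a large group, brings no return below the limit in this assay; compound 3 and compound 4 both stand at a limit, so the step between them cannot be read. The 4-methoxyphenyl ring therefore stays well apart from both rings that gave numbers, with an at least 13-fold higher number from compound 2 to compound 4 (1.12 log units; beyond the scatter) and an at least 56-fold higher number from compound 1 to compound 4 (1.75 log units; beyond the scatter), and both sizes are bounds only. A substituent on this ring is thus not enough in itself for a number under the limit, and only the 2-sulfanylphenyl of compound 1 and the 2-amino-5-nitrophenyl of compound 2 give one, while the rest of the series sits at the limit: the limit of > 80000 nM in this assay, at which 2 of the 4 values shown sit.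

The compounds shown leave open whether a lone amine or a sulfanyl group on the carbon that holds methoxy in compound 4 would bring the number under the limit, and how much the nitro group adds to the amine in compound 2. A hydroxyl group or a carboxylic acid on this ring would test whether the return seen with compound 1 and compound 2 extends to other groups carrying a hydrogen on a heteroatom.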